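Methoxyphenyl shift on an amide-type ring nitrogen

The compounds below may be only part of what the source reports. "The series", "measured", "known", "first", "only" and "open" are said of these compounds alone.

Compound 3 `COc1ccc(N2C(=O)COc3ccc(-c4cnc(Cl)c(NS(=O)(=O)c5ccc(F)cc5)c4)cc32)cc1` and compound 1 `COc1cccc(N2C(=O)COc3ccc(-c4cnc(Cl)c(NS(=O)(=O)c5ccc(F)cc5)c4)cc32)c1` share one core and differ only at the amide-type nitrogen in a ring. In a functional assay on HCT-116 cells (Homo sapiens) for antiproliferative activity, read by MTT assay, with a stated time of 72 h (a lower number here means a stronger inhibitor, a higher number a weaker inhibitor), compound 3 gives 30100 nM. Compound 1 reaches only a limit of this assay, > 40000 nM (the limit of > 40000 nM in this assay, at which 1 of the 3 values shown sits). The change 3-methoxyphenyl in place of 4-methoxyphenyl on an amide-type nitrogen in a ring therefore made an at least 1.3-fold higher number from compound 3 to compound 1 (0.12 log units; that floor lies within the scatter). Compound 2 `COc1ccc(N2C(=O)COc3ccc(-c4ccc(O)cc4)cc32)cc1` rests on another core; the difference between the two cores is not broken down here. In this assay compound 2 gives 26100 nM. Compound 4 `COc1cccc(N2C(=O)COc3ccc(-c4ccc(O)cc4)cc32)c1` is not yet measured and carries the same kind of change, (3-methoxyphenyl in place of 4-methoxyphenyl on an amide-type nitrogen in a ring), at the same place. The step from compound 2 to compound 4 is expected to be a 1.4-fold higher number from compound 2 to compound 4 (0.14 log units; within the scatter), resting on the measured step of an at least 1.3-fold higher number from compound 3 to compound 1 (0.12 log units; that floor lies within the scatter). Compound 4 is estimated at 36000 nM, within 15000 nM to 90000 nM.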

Compound 4, half-maximal inhibitory concentration: 15300 nM
Compound 4: middle estimate off by 2.4-fold (0.37 log units), on the high side; the range from low to high includes it.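

In this assay, the shift from 4-methoxyphenyl to 3-methoxyphenyl on the amide-type ring nitrogen gives a 1.7-fold lower number from compound 2 to compound 4 (0.23 log units; within the scatter). Set beside the earlier step, the comparison stays unresolved: the same change on two cores in this assay, an at least 1.3-fold higher number (0.12 log units; that floor lies within the scatter) from compound 3 to compound 1 and a 1.7-fold lower number (0.23 log units; within the scatter) from compound 2 to compound 4; the limit leaves it open whether they differ. These two pairs therefore do not show that the change carries over from one core to the other, nor do they show that it behaves differently on the two cores.

The compounds shown leave open how this change would read on a third core. They also leave open how an amine or a carboxylic acid in place of the methoxy group on that phenyl ring would read in this assay.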